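Stereoisomers of one core in an M5 binding assay

The source may report more compounds than this note shows. Statements on the series, on what has been measured and on what is new or still open speak of the compounds shown alone.

Measured compounds:
Compound 1 `C[C@@H]1O[C@H]([C@H]2CCCN2C)C[S@@+]1[O-]`: in a binding assay on CHO cells for binding affinity to muscarinic acetylcholine receptor M5 (Homo sapiens) (a lower number here means a stronger inhibitor, a higher number a weaker inhibitor), compound 1 gives only a limit, < 100000 nM.
Compound 2 `C[C@H]1O[C@@H]([C@@H]2CCCN2C)C[S@@+]1[O-]`: in this assay compound 2 gives only a limit, < 100000 nM.
Compound 3 `C[C@@H]1O[C@H]([C@H]2CCCN2C)C[S@+]1[O-]`: in this assay compound 3 gives only a limit, < 100000 nM.

Compound 3 therefore stands nowhere definite on the numbers shown; its value is a limit of the assay, as are the two other values, which is the limit of < 100000 nM in this assay, at which 3 of the 3 values shown sit. Compound 4 `C[C@@H]1O[C@H]([C@@H]2CCCN2C)C[S@@+]1[O-]` differs from compound 3 by the two compounds have the same atoms and bonds and differ only in configuration as drawn: 2 of 4 stereo elements differ; a stereocentre at a saturated ring carbon is drawn R in compound 3 and S in compound 4; a stereocentre at a sulfur is drawn S in compound 3 and R in compound 4. For the measured compounds named here, the steps that bear on this are all between stereoisomers: a step that the two limits leave unreadable from compound 1 to compound 2, a step that the two limits leave unreadable from compound 1 to compound 3 and a step that the two limits leave unreadable from compound 2 to compound 3. None of them is readable, so no direction beyond the scatter can be expected in this assay. Compound 4 is estimated at 30000 nM, between 5000 nM and 100000 nM, and the step from compound 3 to compound 4 is expected to be a step that the limit leaves unreadable from compound 3 to compound 4.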

Compound 4, inhibition constant: < 100000 nM
Compound 4: only a limit was reported (the forecaster's own chance of this, stated with the estimate: 70%); the middle value does not contradict the limit.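

For the compounds shown here, with compound 4 also reported only as a limit in this assay, no step among compound 1, compound 2, compound 3 and compound 4 can be read. The compounds shown leave open how configuration bears on binding affinity.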